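Benzyl in place of pyridin-4-yl on the piperazine nitrogen

This account rests on a few compounds, and the source may have more. Where it says the series, first, only, none or still open, it means among the compounds named here.

Measured compounds:
- compound 1, `COc1ccc(N2CCN(C(=S)SCc3ccc(C(=O)Nc4ccccc4N)cc3)CC2)cc1`, 35.9%
- compound 2, `CN1CCN(C(=S)SCc2ccc(C(=O)Nc3ccccc3N)cc2)CC1`, 91.6%
- compound 3, `Nc1ccccc1NC(=O)c1ccc(CSC(=S)N2CCN(c3ccncc3)CC2)cc1`, 90.7%

In a functional assay on A-375 cells (Homo sapiens) for antiproliferative activity, read by CCK-8 assay, with a stated time of 72 h, tested at 8 uM (a higher number here means a stronger effect of the compound at the concentration tested, a lower number a weaker effect), compound 3 gives 90.7%, the second highest of the three numbers; its nearest neighbour is compound 2, within the scatter, and its furthest is compound 1, far below it. Compound 4, `Nc1ccccc1NC(=O)c1ccc(CSC(=S)N2CCN(Cc3ccccc3)CC2)cc1`, has not been measured. It differs from compound 3 at the ring nitrogen: benzyl in place of pyridin-4-yl on an amine nitrogen in a ring.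

Among the measured compounds shown here, two measured steps bear on this change. Both a number 55.7 percentage points higher from compound 1 to compound 2 (beyond the scatter) and a number 54.8 percentage points higher from compound 1 to compound 3 (beyond the scatter) show that exchanging 4-methoxyphenyl on that nitrogen for a small or a heteroaromatic group raised the read-out strongly, while a number 0.9 percentage points lower from compound 2 to compound 3 (within the scatter) shows methyl and pyridin-4-yl give the same number. Benzyl carries a carbon-only aromatic ring, yet is not the same as the 4-methoxyphenyl of compound 1, so the direction is uncertain. The expected step is a number 20.7 percentage points lower from compound 3 to compound 4 (beyond the scatter), a decrease of moderate size with wide uncertainty. Compound 4 is estimated at 70%, between 35% and 95%.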

Compound 4, a percentage reported as inhibition, at one concentration (the size of the read-out at that concentration, not a potency): 29.3%
Estimate against measurement, compound 4: 40.7 percentage points above, and the stated range ends above it.
By their numbers in this assay, from the lowest: compounds 4 and 1 (each within the scatter of the next); then compounds 3 and 2 (each within the scatter of the next).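

In this assay, the steps of a number 61.4 percentage points lower from compound 3 to compound 4 (beyond the scatter) and a number 62.3 percentage points lower from compound 2 to compound 4 (beyond the scatter) show that the high read-out on this amine nitrogen does not extend to benzyl, and the second step marks the loss on adding phenyl to the methyl of compound 2. The step of a number 6.6 percentage points lower from compound 1 to compound 4 (within the scatter) places benzyl with 4-methoxyphenyl, so the low read-out is not peculiar to the group in compound 1. Among these four compounds, the two groups with a ring of carbon only give low read-outs, while methyl and pyridin-4-yl give high read-outs, and no compound shown goes against this.

The compounds shown offer no explanation for these steps. As far as these compounds go, it remains open how a pyridin-4-ylmethyl group or an ethyl group on this nitrogen would read, and so whether the ring nitrogen or the added carbon link separates compound 4 from compound 3.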